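Trifluoromethyl in place of chloro on compound 2

A few compounds are considered here, and "the series" means these few. Any claim that something is new, unique, unknown or untested is made for them only; others in the source may bear on it.

In a functional assay on HepG2 cells (Homo sapiens) for cytotoxicity, with a stated time of 24 h (on this read-out higher numbers stand for weaker inhibition and lower numbers for stronger inhibition), compound 2 `COc1cc(Cl)ccc1C(=S)Nc1cc(Cl)ccc1O` gives 8490 nM, the middle of three numbers. Compound 1 `COc1cc(Cl)ccc1C(=O)Nc1cc(C(F)(F)F)ccc1O` lies higher at 25400 nM, and compound 3 `COc1cc(Cl)ccc1C(=S)Nc1cc(Cl)c(Cl)cc1O` lies lower at 3160 nM. Compound 4 `COc1cc(Cl)ccc1C(=S)Nc1cc(C(F)(F)F)ccc1O` has trifluoromethyl in place of chloro on an aromatic carbon, para to a hydroxy group: trifluoromethyl in place of chloro on an aromatic carbon. For the measured compounds named here, no measured step covers this exchange. The only one, a 2.7-fold lower number from compound 2 to compound 3 (0.43 log units; beyond the scatter), is modest and adds chloro in place of hydrogen. Compound 1 carries the trifluoromethyl, but with a carbonyl where compound 4 has a thiocarbonyl, so compound 1 at 25400 nM gives no clean guide. The expected change is none beyond the scatter, with an estimated 1.2-fold lower number from compound 2 to compound 4 (0.08 log units; within the scatter). For compound 4 the estimate is 7000 nM, with an expected range of 2500 nM to 19000 nM.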

Compound 4, half-maximal inhibitory concentration: 5740 nM
Estimate against measurement, compound 4: 1.2-fold (0.09 log units) above, within the range that was stated.
By their numbers in this assay, from the lowest: compounds 3, 4 and 2 (each within the scatter of the next, the first and the last beyond it); then compound 1.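

In this assay, trifluoromethyl in place of chloro on an aromatic carbon, para to a hydroxy group, gives a 1.5-fold lower number from compound 2 to compound 4 (0.17 log units; within the scatter), so with the thiocarbonyl kept the read-out does not separate these two groups at this position. With trifluoromethyl at this position, compound 1, with its carbonyl, gives 25400 nM and compound 4, with its thiocarbonyl, gives 5740 nM. Nothing available gives a reason for the result of this exchange.

Open, going by these compounds, is whether an amine or a carboxylic acid at this position would read like chloro and trifluoromethyl. Also open, on these data alone, is how chloro at this position reads with a carbonyl in place of the thiocarbonyl.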